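Triazole aryl swap on a dibenzyloxy lactone scaffold

The source may hold more compounds than are shown below. What is called first, only, known or untested is meant among the compounds shown, and "the series" means these compounds.

Measured compounds:
compound 1, `O=C1O[C@H]([C@@H](O)Cn2cc(-c3cc(C(F)(F)F)cc(C(F)(F)F)c3)nn2)C(OCc2ccccc2)=C1OCc1ccccc1`, 45900 nM 
compound 2, `O=C1O/C(=C\Cn2cc(-c3cc(F)cc(F)c3)nn2)C(OCc2ccccc2)=C1OCc1ccccc1`, > 100000 nM 
compound 3, `O=C1O[C@H]([C@@H](O)Cn2cc(-c3cccc(O)c3)nn2)C(OCc2ccccc2)=C1OCc1ccccc1`, 51800 nM 

Three compounds share the dibenzyloxy lactone core and differ in the aryl group on the triazole and in the linker. In a functional assay on MCF7 cells (Homo sapiens) for antiproliferative activity, read by MTT assay, with a stated time of 72 h (a lower number here means a stronger inhibitor, a higher number a weaker inhibitor), compound 1 gives 45900 nM and compound 3 gives 51800 nM. The two values sit within the scatter of each other, so neither can be ranked against the other. For compound 2 the result is only a limit of this assay, > 100000 nM, as the limit of > 100000 nM in this assay, at which 1 of the 3 values shown sits, records. Compound 3 thus holds the highest of the two numbers, with compound 1 nearest.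

Compound 4, `CCCCCc1ccc(-c2cn(C[C@H](O)[C@H]3OC(=O)C(OCc4ccccc4)=C3OCc3ccccc3)nn2)cc1`, is not yet measured. It differs from compound 3 by 4-pentylphenyl in place of 3-hydroxyphenyl on an aromatic carbon. Within the data shown here, no measured pair isolates such a change, so no direction can be read from the numbers already in hand. The two numbered values lie close together, and the expectation is for a step in this assay that stays near the scatter rather than one clearly beyond it. Compound 4 is therefore estimated at 40000 nM, within a range from 10000 nM to 120000 nM, which corresponds to an expected step of a 1.3-fold lower number from compound 3 to compound 4 (0.11 log units; within the scatter).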

Compound 4, half-maximal inhibitory concentration: 9010 nM
Compound 4: middle estimate off by 4.4-fold (0.65 log units), on the high side, and the stated range ends above it.
By their numbers in this assay, from the lowest: compound 4; then compounds 1 and 3 (each within the scatter of the next). At a limit, above all of these: compound 2.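

In this assay, putting 4-pentylphenyl in place of 3-hydroxyphenyl on this aromatic carbon of the five-membered aromatic ring with 3 nitrogen gives a 5.7-fold lower number from compound 3 to compound 4 (0.76 log units; beyond the scatter). This is the only change at this position among the compounds shown that can be read as a step beyond the scatter, since compound 1 at 45900 nM and compound 3 at 51800 nM lie within the scatter of each other, so the aryl group here can matter in this assay even though those two aryl groups did not separate. The change removes the hydroxyl and adds the pentyl chain in one move, and nothing measured here accounts for the step.

The compounds shown leave open whether the step follows the pentyl chain or simply the loss of the hydroxyl, a question that a plain phenyl, a 4-methylphenyl or a longer chain such as 4-octylphenyl on the same carbon would address. They also leave open how an amine or a carboxylic acid at the end of that chain would read in this assay.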